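Ethoxymethyl for ethoxycarbonyl: working notes on compound 4

The source may hold more compounds than are shown below. What is called first, only, known or untested is meant among the compounds shown, and "the series" means these compounds.

In a functional assay on KB cells (Homo sapiens) for cytotoxicity, read by MTT assay, with a stated time of 72 h (a higher number here means that more compound is needed for the effect, a lower number that less compound is needed), compound 1 `CCc1cccc2c(O)c(-c3occ(C)c3C(=O)O)ccc12` gives 9.1 ug/mL, while compound 2 `CCOC(=O)c1c(C)coc1-c1ccc2c(CC)cccc2c1OC` gives 2.2 ug/mL. Compound 2 holds the lower of the two numbers in the series, and the gap between them lies beyond the scatter. Compound 3 `CCc1cccc2c(OC(C)=O)c(-c3occ(C)c3COC(C)=O)ccc12` returns only a limit, > 10 ug/mL. Compound 4 `CCOCc1c(C)coc1-c1ccc2c(CC)cccc2c1OC` keeps the core of compound 2 and carries ethoxymethyl in place of ethoxycarbonyl on an aromatic carbon. Among the compounds with values here, no measured pair isolates this change, so any expectation is loose. Compound 3 also has no carbonyl directly on that aromatic carbon, but it differs from compound 2 elsewhere as well. The limit of compound 3, > 10 ug/mL, gives only a weak hint toward a higher number. On that thin basis, a small move toward a higher number in this assay is expected, with the estimated change being a 1.8-fold higher number from compound 2 to compound 4 (0.26 log units; within the scatter). The range is kept wide and reaches down past the value of compound 2, since a gain cannot be excluded. For compound 4 the expected value is 4 ug/mL, with an estimated range of 1.5 ug/mL to 10 ug/mL.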

Compound 4, concentration for half-maximal effect: > 10 ug/mL
Compound 4: a limit, no number (the forecaster's own chance of this, stated with the estimate: 15%); at least 2.5-fold (0.39 log units) between middle value and limit.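

Within the data shown here, the first single change at this position can now be read. In this assay, replacing ethoxycarbonyl with ethoxymethyl on the aromatic carbon gives an at least 4.5-fold higher number from compound 2 to compound 4 (0.65 log units; beyond the scatter), so the shared core alone does not hold the lower number of compound 2, and the group at this place counts. Compound 3 could not show this, as it also lacks a carbonyl directly on that carbon but differs from compound 2 elsewhere as well, whereas here the change is the only one, and the step lies beyond the scatter. Its true size stays unknown, since one end of it is set by a limit of the assay and not by a number: the limit of > 10 ug/mL in this assay, at which 2 of the 4 values shown sit.

The compounds shown do not tell whether the carbonyl alone matters or the ester as a whole, as an amide or a ketone on this aromatic carbon would separate the two. On these data alone, how far the ethyl part of the ester can vary is also open, and a methyl ester or a longer chain in its place would bear on that.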